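This account rests on a few compounds, and the source may have more. Where it says the series, first, only, none or still open, it means among the compounds named here.

Measured so far:
Compound 1, `O=C1c2ccccc2C(=O)N1CCCCN1CCN(c2cccc3ccccc23)CC1`, in an assay on frontal cortex for binding affinity to Adrenergic receptor alpha-1 (Rattus norvegicus), read by radioligand binding (a lower number here means a stronger inhibitor, a higher number a weaker inhibitor), gives 22 nM.
Compound 2, `CC(=O)Nc1ccc(N2CCN(CCCCN3C(=O)c4ccccc4C3=O)CC2)cc1`, gives < 1000 nM in this assay, which is a limit of the assay and not a number.
Compound 3, `COc1ccccc1N1CCN(CCCCNC(=O)c2ccc(I)cc2)CC1`, gives 15 nM in this assay.

Compound 3 and compound 1 lie within the usual scatter of each other in this assay, so neither can be called the stronger binder. Compound 2 sits at the limit of < 1000 nM in this assay, at which 1 of the 3 values shown sits, so only a limit is known for it. Among the measured compounds shown here, the one step measured, a step that the limit leaves unreadable from compound 1 to compound 2, concerns the group on the piperazine nitrogen, and its size cannot be read since compound 2 sits at the limit of < 1000 nM in this assay, at which 1 of the 3 values shown sits.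

Compound 4, `CCCCC(=O)NCCCCN1CCN(c2ccccc2OC)CC1`, has not yet been measured. It differs from compound 3 at the amide end: butyl in place of 4-iodophenyl on a carbonyl carbon. For the measured compounds named here, no measured step touches this carbonyl side of the molecule, so nothing measured shows how this assay responds to it. The expectation therefore rests on compound 3 alone, with 15 nM as the anchor and a wide range. The step of a 4.0-fold higher number from compound 3 to compound 4 (0.60 log units; beyond the scatter) is estimated, an expected loss beyond the scatter. For compound 4 a value of 60 nM is expected, between 15 nM and 300 nM.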

Compound 4, inhibition constant: 84 nM
Beside the measured number, compound 4's estimate is 1.4-fold (0.15 log units) below it; low and high end bracket the measured number.
By their numbers in this assay, from the lowest: compounds 3 and 1 (each within the scatter of the next); then compound 4.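

Butyl in place of 4-iodophenyl on a carbonyl carbon gives a 5.6-fold higher number from compound 3 to compound 4 (0.75 log units; beyond the scatter) in this assay and is the first readable step at this end of the molecule, showing that the group on this carbonyl carbon does affect the number. The change is modest, though: compound 4, which has no ring at this place, still gives 84 nM in this assay, so among the compounds shown, a ring on this carbonyl carbon is not needed for a number in the nanomolar range. No measured property of either group bears on this step, so the data offer no explanation for it.

The change removes the ring and the iodine together and also alters the number of heavy atoms, so the compounds shown cannot say which of these differences accounts for the step. A plain phenyl on the same carbonyl carbon would separate the iodine from the ring, while a cyclohexyl or a longer chain such as hexyl would test whether the ring's aromatic character or the size of the group matters more.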